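Moving the chlorine around the ring of compound 1

The source may hold more compounds than are shown below. What is called first, only, known or untested is meant among the compounds shown, and "the series" means these compounds.

Compound 1 `Oc1cc(C(F)(F)F)ccc1-c1nc(-c2ccccc2O)n(-c2ccc(Cl)cc2)n1` was tested in a functional assay on PC-12 cells (Rattus norvegicus) for cytotoxicity, read by MTT assay, with stated times of 2 h and 24 h, tested at 1 uM (a lower number here means a weaker effect, a higher number a stronger effect of the compound at the concentration tested), where compound 1 gives 68%. Among the three measured compounds it stands second highest, though all three lie within the usual scatter of one another. Compound 2 `Oc1cc(C(F)(F)F)ccc1-c1nc(-c2ccccc2O)n(-c2ccc(I)cc2)n1` gives 70.1%, and the change a number 2.1 percentage points higher from compound 1 to compound 2 (within the scatter). Compound 3 `Oc1cc(C(F)(F)F)ccc1-c1nc(-c2ccccc2O)n(-c2ccc(OC(F)(F)F)cc2)n1` gives 65.5%, and the change a number 2.5 percentage points lower from compound 1 to compound 3 (within the scatter).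

Compound 4 `Oc1cc(C(F)(F)F)ccc1-c1nc(-c2ccccc2O)n(-c2cccc(Cl)c2)n1` has not yet been measured. It differs from compound 1 in a single place: 3-chlorophenyl in place of 4-chlorophenyl on an aromatic nitrogen. Within the data shown here, the measured steps all exchange one group for another at the same place on the ring, and each of them stayed within the scatter; none of them moves the chlorine to another position of that ring, so no measured step bears directly on this change. With every shown step small, the expected change for compound 4 is no change at the digits printed from compound 1 to compound 4 (within the scatter), that is, none beyond the scatter. Compound 4 is therefore estimated at 68%, with a range from 56% to 80%.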

Compound 4, a percentage reported as activity, at one concentration (the size of the read-out at that concentration, not a potency): 72.3%
Estimate against measurement, compound 4: 4.3 percentage points below, and the stated range covers the measured number.
By their numbers in this assay, from the lowest: compounds 3, 1, 2 and 4 (each within the scatter of the next).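

Moving the chlorine from 4-chlorophenyl to 3-chlorophenyl on the aromatic nitrogen is the first measured shift of a group around this ring, and in this assay it gives a small step (a number 4.3 percentage points higher from compound 1 to compound 4 (within the scatter)), so no effect of the chlorine's position on this ring can be told apart from the scatter. Compound 4 also stays close to the compounds with other groups in this place (a number 6.8 percentage points higher from compound 3 to compound 4 (within the scatter); a number 2.2 percentage points higher from compound 2 to compound 4 (within the scatter)), and this place has so far tolerated every change shown without a step beyond the scatter. No measurement at hand offers an explanation for these small steps.

From the compounds shown here alone, what an amine, a carboxylic acid or a longer chain on this phenyl ring would do in this assay stays open. The shared core is the same in every compound shown, so what its own groups contribute stays open too.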